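The source may report more compounds than this note shows. Statements on the series, on what has been measured and on what is new or still open speak of the compounds shown alone.

Measured so far:
- compound 1, `O=[N+]([O-])c1ccccc1NC(CO)CO`: in a functional assay on CNE cells (Homo sapiens) for cytotoxicity (a higher number here means a weaker inhibitor, a lower number a stronger inhibitor), compound 1 gives > 100000 nM, which is a limit of the assay rather than a number.
- compound 2, `O=[N+]([O-])c1ccc(NC(CO)CO)c([N+](=O)[O-])c1`: in this assay compound 2 gives > 100000 nM, again a limit of the assay.

Compound 2 therefore stands at the limit, as does compound 1; both values sit at the limit of > 100000 nM in this assay, at which 2 of the 2 values shown sit, so nothing about the relative standing of the two can be read. Among the measured compounds shown here, the only step between measured compounds, a step that the two limits leave unreadable from compound 1 to compound 2, is unreadable for the same reason.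

Compound 3, `O=[N+]([O-])c1cc(C(F)(F)F)ccc1NC(CO)CO`, differs from compound 2 by trifluoromethyl in place of nitro on an aromatic carbon. For the measured compounds named here, no measured step bears on a change of this kind: the single step available is itself hidden behind two limits, and neither value gives a foothold for a direction. The expectation for compound 3 in this assay is accordingly a step that the limit leaves unreadable from compound 2 to compound 3, which means no movement beyond the scatter from the position of compound 2. Compound 3 is estimated at 150000 nM, with a range from 40000 nM to 600000 nM, and most likely again only a limit is reported.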

Compound 3, half-maximal inhibitory concentration: > 100000 nM
Compound 3 gave a limit, no number (the forecaster's own chance of this, stated with the estimate: 85%); the middle value is on the limit's open side.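

In this assay compound 3 gives > 100000 nM, a limit of the assay and not a number. No step among compound 1, compound 2 and compound 3 can be read, because all three stand at the same limit: the limit of > 100000 nM in this assay, at which 3 of the 3 values shown sit.

The compounds shown leave open how the three rank against one another and whether any change to the shared core gives a readable value in this assay.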